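Series notes: butoxy replaced by trifluoromethyl

The compounds below may be only part of what the source reports. "The series", "measured", "known", "first", "only" and "open" are said of these compounds alone.

Results in a functional assay on HeLa cells (Homo sapiens) for cytotoxicity, read by WST assay, with a stated time of 48 h (a higher number here means that more compound is needed for the effect, a lower number that less compound is needed), so far:
compound 1 `O=C1OC[C@H](Cc2ccccc2)[C@H]1Cc1ccc(OC(F)(F)F)cc1` gives "not determined" (no result reported)
compound 2 `COCOc1ccc(C[C@H]2C(=O)OC[C@@H]2Cc2ccccc2)cc1` gives "not determined" (no result reported)
compound 3 `CCCCOc1ccc(C[C@H]2C(=O)OC[C@@H]2Cc2ccccc2)cc1` gives 27000 nM

Among the compounds with values here, compound 3 holds the only number in this set, so it cannot be placed high or low against any neighbour. Within the data shown here, compound 1 and compound 2 returned no result, and no measured step exists between any two compounds. The series therefore offers no trend to extend.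

Compound 4 `O=C1OC[C@H](Cc2ccccc2)[C@H]1Cc1ccc(C(F)(F)F)cc1` is still to be measured in this assay and differs from compound 3 in one place (trifluoromethyl in place of butoxy on an aromatic carbon), with trifluoromethyl in place of butoxy on an aromatic carbon, para to a large group. Among the measured compounds shown here, the data contain no measured example of this replacement, and no direction for it can be read from them. The estimated step is small (a 1.1-fold higher number from compound 3 to compound 4 (0.05 log units; within the scatter)), and no shift beyond the usual scatter is expected. This expectation rests on compound 3 alone (27000 nM), which leaves the estimate poorly constrained, so a wide range is appropriate. The expected value for compound 4 is 30000 nM (estimated range 10000 nM to 90000 nM).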

Compound 4, half-maximal effective concentration: 29000 nM
Compound 4: middle estimate off by 1.0-fold (0.01 log units), on the high side; low and high end bracket the measured number.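

Trifluoromethyl in place of butoxy on an aromatic carbon, para to a large group, gives the first readable step in this series: in this assay the change is a 1.1-fold higher number from compound 3 to compound 4 (0.03 log units; within the scatter) and stays within the usual scatter. This pair shows that the number does not separate the two groups at this position, even though the heavy-atom count goes from 5 to 4, the hydrogen-bond acceptor count goes from 1 to 0, and the chain gives way to a group with no carbon chain at all. No measured property of either group bears on this result, and the data give no reason for the absence of a shift.

Within the data shown here, with compound 1 and compound 2 reporting no result, their steps cannot be read, so this single pair is the only measured comparison at the position and supports no wider pattern. As far as these compounds go, whether an amine, a carboxylic acid or a chain longer than butoxy on the same aromatic carbon would move the number beyond the scatter remains open, as does any change on the unsubstituted phenyl side of the shared core.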